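The compounds below may be only part of what the source reports. "The series", "measured", "known", "first", "only" and "open" are said of these compounds alone.

Measured compounds:
Compound 1, `COC(=O)c1c(-c2ccc([N+](=O)[O-])cc2)oc2ccccc2c1=O`: in a functional assay on Malme-3M cells (Homo sapiens) for cytotoxicity, read by MTT assay, with a stated time of 6 days (a lower number here means that less compound is needed, a higher number that more compound is needed for the effect), compound 1 gives > 25 ug/mL, which is a limit of the assay rather than a number.
Compound 2, `COC(=O)c1c(-c2ccc([N+](=O)[O-])cc2)oc2cc(OC)ccc2c1=O`: in this assay compound 2 gives 1.12 ug/mL.
Compound 3, `COC(=O)c1c(-c2ccc(O)cc2)oc2cc(OC)ccc2c1=O`: in this assay compound 3 gives 20.1 ug/mL.

Compound 2 gives the lowest of the two numbers reported in this assay; the nearest is compound 3, with an 18-fold higher number from compound 2 to compound 3 (1.25 log units; beyond the scatter). The other measured step, an at least 22-fold lower number from compound 1 to compound 2 (1.34 log units; beyond the scatter), is also large. Both steps show that a single change on this core can move the result a long way.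

Compound 4, `COc1ccc2c(=O)c(C(=O)O)c(-c3ccc([N+](=O)[O-])cc3)oc2c1`, differs from compound 2 at another place: hydrogen in place of methyl on an oxygen next to a carbonyl group. Going by the values given here, neither measured step touches this position, so no step here bears directly on it; the two steps only show how large a single change can be. Without a direct precedent, the expectation for compound 4 is a higher number than compound 2, of uncertain size, estimated as a 7.1-fold higher number from compound 2 to compound 4 (0.85 log units; beyond the scatter). Compound 4 is therefore expected to give about 8 ug/mL in this assay, within a wide range from 1.5 ug/mL to 25 ug/mL.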

Compound 4, concentration for half-maximal effect: > 25 ug/mL
Compound 4: a limit, no number; the forecaster's own chance of this, stated with the estimate: 35%; at least 3.1-fold (0.49 log units) between middle value and limit.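

This position had not been changed in any earlier step, and it proves sensitive: in this assay, going from methoxycarbonyl to carboxy gives an at least 22-fold higher number from compound 2 to compound 4 (1.34 log units; beyond the scatter). Compound 4 gives > 25 ug/mL, which is a limit of the assay and not a number. The step therefore shows only a minimum size, because the result sits at that limit: the limit of > 25 ug/mL in this assay, at which 2 of the 4 values shown sit.

The compounds shown leave open whether a longer chain on this oxygen, such as ethyl, would keep a number close to that of compound 2, or whether an amide in place of the ester would do so. They also do not show whether the loss comes from removing the methyl as such or from the carboxylic acid that results.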